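Acetate ester in place of a free hydroxyl group

This account rests on a few compounds, and the source may have more. Where it says the series, first, only, none or still open, it means among the compounds named here.

Compounds measured so far:
compound 1 `O=C(CCCc1ccccc1)OC(CCN1CCN(CCCN(c2ccc(F)cc2)c2ccc(F)cc2)CC1)c1ccccc1` gives 51.3 nM
compound 2 `C=CC(=O)O[C@@H](Cc1ccccc1)CN1CCN(CCCN(c2ccc(F)cc2)c2ccc(F)cc2)CC1` gives 3.26 nM
compound 3 `O[C@H](Cc1ccccc1)CN1CCN(CCCN(c2ccc(F)cc2)c2ccc(F)cc2)CC1` gives 5.36 nM

In an assay on membranes from striatum for displacement of a labelled ligand from sodium-dependent dopamine transporter (Rattus norvegicus) (on this read-out lower numbers stand for stronger inhibition and higher numbers for weaker inhibition), compound 3 gives 5.36 nM, the second highest of the three numbers. Its nearest neighbour is compound 2, whose value is within the scatter, so the two cannot be told apart. Compound 1 stands furthest away, with a clearly higher number, beyond the scatter. Compound 4 `CC(=O)OC(CCN1CCN(CCCN(c2ccc(F)cc2)c2ccc(F)cc2)CC1)c1ccccc1` has not yet been measured in this assay. It differs from compound 3 in one place: 2-acetoxy-2-phenylethyl in place of 1-hydroxy-2-phenylethyl on a saturated chain carbon bound to an amine nitrogen in a ring. Compound 4 thus carries an ester where compound 3 carries a free hydroxyl, and its arrangement of phenyl and ester on the chain matches that of compound 1, which is the weakest of the three measured compounds. The expectation is therefore a step towards a higher number, of size a 3.7-fold higher number from compound 3 to compound 4 (0.57 log units; beyond the scatter), beyond the scatter but short of the value of compound 1. Compound 4 is estimated at 20 nM, within a range from 5 nM to 80 nM.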

Compound 4, inhibition constant: 4.28 nM
Beside the measured number, compound 4's estimate is 4.7-fold (0.67 log units) above it; measured number below the stated range.
By their numbers in this assay, from the lowest: compounds 2, 4 and 3 (each within the scatter of the next); then compound 1.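

In this assay, an ester can replace the free hydroxyl at this position with no readable effect: 2-acetoxy-2-phenylethyl in place of 1-hydroxy-2-phenylethyl gives a 1.3-fold lower number from compound 3 to compound 4 (0.10 log units; within the scatter), so the two compounds cannot be told apart. The large change lies elsewhere, as hydrogen in place of phenethyl on a saturated chain carbon bound to a carbonyl carbon gives a 12-fold lower number from compound 1 to compound 4 (1.08 log units; beyond the scatter). Within this pair, then, the weaker binding goes with the phenethyl-bearing ester chain, and the step from compound 3 shows that it does not come from having an ester as such. No evidence is available to explain either step.

From the compounds shown here alone, it remains open whether a methyl ether or an amide would match the acetate ester here. A propanoate or butanoate ester could show how far the ester chain can grow before the number rises.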